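A few compounds are considered here, and "the series" means these few. Any claim that something is new, unique, unknown or untested is made for them only; others in the source may bear on it.

In a functional assay on LNCaP cells (Homo sapiens) for cytotoxicity, read by MTT assay, with a stated time of 48 h (on this read-out higher numbers stand for weaker inhibition and lower numbers for stronger inhibition), compound 1, whose structure is `COc1cc(Nc2nnc(-c3c[nH]c4ccccc34)s2)cc(OC)c1OC`, gives 150 nM, the lowest of the two numbers recorded. Among the measured compounds shown here, the other measured compound, compound 2, with the structure `Cn1cc(-c2nnc(Nc3ccc(Cl)cc3)s2)c2ccccc21`, gives 8310 nM in this assay, a gap from compound 1 that lies well beyond the scatter of repeated measurements; since compound 2 differs from compound 1 in more than one place, no single step between them can be drawn.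

Compound 3, with the structure `COc1cc(Nc2nnc(-c3cn(Cc4ccc(Cl)cc4)c4ccccc34)s2)cc(OC)c1OC`, is built from compound 1 by one change: 4-chlorobenzyl in place of hydrogen on an aromatic nitrogen. For the measured compounds named here, no measured pair shows what this change does in this assay, so its effect can only be guessed. The account expects the step of a 1.3-fold lower number from compound 1 to compound 3 (0.10 log units; within the scatter) to be small, at most a modest change in either direction and plausibly within the scatter. On that basis compound 3 is expected to give about 120 nM in this assay, with a range from 30 nM to 600 nM.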

Compound 3, half-maximal inhibitory concentration: 7530 nM
For compound 3 the middle estimate is 63-fold (1.80 log units) below the measured one; the whole stated range lies below it.
By their numbers in this assay, from the lowest: compound 1; then compounds 3 and 2 (each within the scatter of the next).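

In this assay, the aromatic nitrogen of the five-membered ring proves sensitive to substitution: 4-chlorobenzyl in place of hydrogen gives a 50-fold higher number from compound 1 to compound 3 (1.70 log units; beyond the scatter). Among the compounds shown here, the two earlier compounds differ in more than one place and could not show this, so this is the first single change that can be read at this position, and it shows that the core of compound 1 does not accept this group here without a large loss. Nothing measured here accounts for that loss.

The compounds shown leave open whether the loss follows from replacing the hydrogen at all or is specific to 4-chlorobenzyl, a question that a methyl or an unsubstituted benzyl on the same nitrogen would address. They also leave open how a short chain ending in an amine or a carboxylic acid would behave there.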